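Methyl for 2-methylcyclopropyl on an amide-type nitrogen

The source may report more compounds than this note shows. Statements on the series, on what has been measured and on what is new or still open speak of the compounds shown alone.

For the measured compounds named here, compound 2 `CNC(=O)c1cc(C(=O)N[C@@H]2C[C@H]2C)cc2c1O[C@H](CF)[C@H]2c1ccccc1` gives 7 ug/mL in a physicochemical assay for solubility (on this read-out higher numbers stand for higher solubility and lower numbers for lower solubility), the only true number so far. Compound 1 `CNC(=O)c1cc(C(=O)N[C@H]2[C@@H]3COC[C@@H]32)cc2c1O[C@H](CF)[C@H]2c1ccccc1` stands at >= 206 ug/mL, which is a limit of the assay. Compound 3 `CNC(=O)c1cc(C(=O)N[C@H]2C[C@@H]2C)cc2c1OC[C@H]2c1ccccc1` stands at >= 76 ug/mL, which is also a limit.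

The next structure is compound 4 `CNC(=O)c1cc(C(=O)NC)c2c(c1)[C@H](c1ccccc1)[C@@H](CF)O2`, with methyl in place of 2-methylcyclopropyl on an amide-type nitrogen. Going by the values given here, only one measured step bears on this change: an at least 29-fold lower number from compound 1 to compound 2 (1.46 log units; beyond the scatter), in which 2-methylcyclopropyl arrives on that nitrogen and the read-out falls by a large margin. The present change takes the same group away, but it puts methyl there rather than the group of compound 1, so only part of that fall is expected to be recovered. One step is thin support for this.

The expected change is a 7.1-fold higher number from compound 2 to compound 4 (0.85 log units; beyond the scatter), upward and beyond the scatter. For compound 4 the estimate in this assay is 50 ug/mL, with an expected range of 14 ug/mL to 180 ug/mL.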

Compound 4, solubility: >= 149 ug/mL
Compound 4 ended at the assay's limit (the forecaster's own chance of this, stated with the estimate: 30%); middle value at least 2.9-fold (0.47 log units) away from the limit.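

In this assay, methyl in place of 2-methylcyclopropyl on the amide-type nitrogen gives an at least 21-fold higher number from compound 2 to compound 4 (1.32 log units; beyond the scatter). Earlier, this position offered only a step in which 2-methylcyclopropyl arrived in place of the group of compound 1; this step shows that a large change on the same core also follows when the ring-free methyl replaces 2-methylcyclopropyl, so the group of compound 1 is not the only one on that nitrogen that stands far from compound 2. Compound 4 gives >= 149 ug/mL, which is a limit of the assay and not a number, so the step sets only a minimum size.

The step from compound 1 to compound 4 cannot be read, which leaves methyl and the group of compound 1 unranked. Going by these compounds, how an ethyl group, a longer chain or a chain ending in an amine on that nitrogen would read remains open.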